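Propyl-substituted xanthine series: next step at the ring carbon

The compounds below may be only part of what the source reports. "The series", "measured", "known", "first", "only" and "open" are said of these compounds alone.

For the measured compounds named here, compound 2 `CCCn1c(=O)c2nc(C(O)(CC)CC)[nH]c2n(CCC)c1=O` gives the lowest number of the two values so far in an assay on cell membranes for binding affinity to adenosine receptor A1 (Cavia porcellus), read by radioligand binding (on this read-out lower numbers stand for stronger inhibition and higher numbers for weaker inhibition), namely 170 nM. Compound 1 `CCCn1c(=O)c2nc(-c3ccco3)[nH]c2n(CCC)c1=O` stands nearest; in this assay compound 1 gives 560 nM. Going by the values given here, the single step between the two, a 3.3-fold lower number from compound 1 to compound 2 (0.52 log units; beyond the scatter), is the only measured step in the set.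

Compound 3 `CCCn1c(=O)c2nc(CC3CC3)[nH]c2n(CCC)c1=O` is not yet measured. The change from compound 2 to compound 3 is cyclopropylmethyl in place of 1-ethyl-1-hydroxypropyl on an aromatic carbon. Among the compounds with values here, no measured step carries this particular exchange; the step from compound 1 to compound 2 shows only that the 1-ethyl-1-hydroxypropyl group gave a lower number than furan-2-yl. Cyclopropylmethyl brings neither the hydroxyl of compound 2 nor the aromatic ring of compound 1, so an estimate has to be a cautious one, leaning towards a somewhat higher number. For compound 3 a value of 300 nM is expected, with a range from 80 nM to 1200 nM. The expected step is a 1.8-fold higher number from compound 2 to compound 3 (0.25 log units; within the scatter).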

Compound 3, inhibition constant: 120 nM
Compound 3: the middle estimate sits 2.5-fold (0.40 log units) above what was measured, within the range that was stated.
By their numbers in this assay, from the lowest: compounds 3 and 2 (each within the scatter of the next); then compound 1.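

In this assay, cyclopropylmethyl in place of 1-ethyl-1-hydroxypropyl gives a 1.4-fold lower number from compound 2 to compound 3 (0.15 log units; within the scatter) and so the hydroxyl of compound 2 is not needed at this ring carbon for a value at this level, since the entering group has 0 hydrogen-bond donors and 0 hydrogen-bond acceptors. Set against furan-2-yl, the same group gives a 4.7-fold lower number from compound 1 to compound 3 (0.67 log units; beyond the scatter) and so both non-aromatic groups now stand beyond the scatter from compound 1, though that compound is the only aromatic example in the set. No supporting data explain why these groups read as they do.

Open, going by these compounds, is whether a plain straight propyl chain, a longer chain, an amine or a carboxylic acid at this carbon would keep this level. A phenyl ring would show whether furan-2-yl speaks for aromatic groups generally.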